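Cyclobutyl on the Amide Nitrogen of Compound 3

A few compounds are considered here, and "the series" means these few. Any claim that something is new, unique, unknown or untested is made for them only; others in the source may bear on it.

Of the compounds shown here, three with a shared core have been measured in a functional assay on LNCaP cells (Homo sapiens) for antiproliferative activity; on this read-out higher numbers stand for weaker inhibition and lower numbers for stronger inhibition. Compound 1 `Cn1ncc(Cl)c1-c1cc(C(=O)N[C@@H]2CN[C@H](CC(O)CO)C[C@H]2c2ccc(F)c(F)c2)oc1Cl` gives 100 nM, compound 2 `Cn1ncc(Cl)c1-c1cc(C(=O)N[C@@H]2CN[C@H](CCO)C[C@H]2c2ccc(F)c(F)c2)oc1Cl` gives 60 nM, and compound 3 `Cn1ncc(Cl)c1-c1cc(C(=O)N[C@@H]2CN[C@H](CC(N)=O)C[C@H]2c2ccc(Cl)c(Cl)c2)oc1Cl` gives 160 nM. Compound 3 stands at the highest of the three numbers: its nearest neighbour is compound 1, a gap that lies within the scatter, while compound 2 is the furthest, with a gap beyond the scatter. Going by the values given here, the only step between measured compounds that differ in one place is a 1.7-fold lower number from compound 1 to compound 2 (0.22 log units; within the scatter).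

Compound 4 `Cn1ncc(Cl)c1-c1cc(C(=O)N[C@@H]2CN[C@H](CC(=O)NC3CCC3)C[C@H]2c2ccc(Cl)c(Cl)c2)oc1Cl` has not yet been measured. It differs from compound 3 in one place: cyclobutyl in place of hydrogen on an amide-type nitrogen. Among the compounds with values here, no measured pair alters a substituent on an amide-type nitrogen; the step from compound 1 to compound 2 concerns a saturated chain carbon instead, so it does not speak to this change, and the data give no guidance on its direction. Lacking any step that bears on it, the step of no change at the digits printed from compound 3 to compound 4 (within the scatter) is expected to stay within the scatter, in either direction. Compound 4 is therefore expected to give about 160 nM in this assay, within a range from 50 nM to 500 nM.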

Compound 4, half-maximal inhibitory concentration: 80 nM
Beside the measured number, compound 4's estimate is 2.0-fold (0.30 log units) above it; the range from low to high includes it.
By their numbers in this assay, from the lowest: compounds 2, 4, 1 and 3 (each within the scatter of the next, the first and the last beyond it).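

Going by these compounds alone, this is the first reading of a substituent on this amide-type nitrogen: in this assay the change gives a 2.0-fold lower number from compound 3 to compound 4 (0.30 log units; within the scatter). Cyclobutyl, with its 4 carbon atoms in one four-membered ring, can therefore stand in place of the amide hydrogen while the number stays within the scatter, so in this assay this position does not depend on keeping that hydrogen. Nothing at hand explains why the number falls where it does.

From the compounds shown here alone, a single step within the scatter cannot show whether the position is indifferent to what it carries, so it remains open how the number would respond to methyl, cyclohexyl or phenyl on the same nitrogen, or to a longer chain ending in an amine or a carboxylic acid. Going by these compounds, it also remains open whether cyclobutyl on this nitrogen would read the same with fluorine in place of chlorine, the halogen carried by compound 1 and compound 2 where compound 3 and compound 4 carry chlorine.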